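From 2-methylphenyl to 4-methylphenyl at the assay limit

A few compounds are considered here, and "the series" means these few. Any claim that something is new, unique, unknown or untested is made for them only; others in the source may bear on it.

Of the compounds shown here, two have been tested so far in an ADME assay on MDBK cells (Bos taurus) for cytotoxicity; on this read-out higher numbers stand for lower toxicity in this test and lower numbers for higher toxicity in this test. Compound 1 `Fc1cccc(F)c1Cn1cccc2nc(-c3c(F)cccc3F)nc1-2` gives > 100000 nM, which is a limit of the assay and not a number. Compound 2 `Cc1ccccc1Cn1ccc2nc(-c3ccccc3)nc-2c1` gives > 100000 nM, which is likewise a limit. Neither compound has a numerical value, and the record so far shows only (the limit of > 100000 nM in this assay, at which 2 of the 2 values shown sit). For the measured compounds named here, no step between measured compounds is available, so compound 2 can be placed only at that limit.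

Compound 3 `Cc1ccc(Cn2ccc3nc(-c4ccccc4)nc-3c2)cc1` has not yet been measured. It differs from compound 2 by 4-methylphenyl in place of 2-methylphenyl on a saturated chain carbon bound to an aromatic nitrogen, with 4-methylphenyl in place of 2-methylphenyl on a saturated chain carbon bound to an aromatic nitrogen. The expected change, a number no higher from compound 2 to compound 3 (the limit leaves the size open), is none beyond the usual scatter, and no direction is favoured. This expectation rests on compound 2, whose reading of > 100000 nM is a limit. Compound 3 will quite likely be reported as a limit too. For compound 3 the estimated value in this assay is 100000 nM, with an expected range from 50000 nM to 150000 nM.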

Compound 3, half-maximal cytotoxic concentration: > 100000 nM
Compound 3: no number, only a limit; the forecaster's own chance of this, stated with the estimate: 85%; the middle value lies on the limit itself.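

Compound 2 and compound 3 both stand at a limit of the assay and not at a number, so no step can be read between them. The compounds shown leave open how far apart their true values lie, and whether any structural change here would give a number, as the record holds only one reading: the limit of > 100000 nM in this assay, at which 3 of the 3 values shown sit.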